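Bromothiophene Replaces Furan on the Enone Carbonyl

The compounds below may be only part of what the source reports. "The series", "measured", "known", "first", "only" and "open" are said of these compounds alone.

Compound 1 `COc1ccc(-c2cc3ccccc3nc2/C=C/C(=O)c2c(OC)cccc2OC)cc1` and compound 2 `COc1ccc(-c2cc3ccccc3nc2/C=C/C(=O)c2ccco2)cc1` share one core and differ only in the aryl group attached to the carbonyl carbon. Going by the values given here, in a functional assay on MCF7 cells (Homo sapiens) for antiproliferative activity, read by XTT assay, with a stated time of 72 h (on this read-out higher numbers stand for weaker inhibition and lower numbers for stronger inhibition), compound 1 gives 4520 nM, while compound 2 gives 710 nM; the step of a 6.4-fold lower number from compound 1 to compound 2 (0.80 log units; beyond the scatter) lies beyond the scatter, so compound 2 stands as the lower of the two numbers measured so far. Compound 3 `COc1ccc(-c2cc3ccccc3nc2/C=C/C(=O)c2ccc(Br)s2)cc1` varies the same position once more: 5-bromothiophen-2-yl in place of furan-2-yl on a carbonyl carbon. Among the compounds with values here, the single measured step that bears on this change is a 6.4-fold lower number from compound 1 to compound 2 (0.80 log units; beyond the scatter), which shows that the aryl group on the carbonyl carbon can move the number, but nothing measured shows how one five-membered aromatic ring compares with another at this place. The expected step is therefore a 1.2-fold lower number from compound 2 to compound 3 (0.07 log units; within the scatter), not beyond the scatter. Compound 3 is accordingly estimated at 600 nM, with a range from 200 nM to 2000 nM.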

Compound 3, half-maximal inhibitory concentration: 910 nM
Compound 3: middle estimate off by 1.5-fold (0.18 log units), on the low side, within the range that was stated.
By their numbers in this assay, from the lowest: compounds 2 and 3 (each within the scatter of the next); then compound 1.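

In this assay the exchange gives a 1.3-fold higher number from compound 2 to compound 3 (0.11 log units; within the scatter), so at this place, on a carbonyl carbon, 5-bromothiophen-2-yl and furan-2-yl cannot be told apart, although sulfur takes the place of oxygen in the ring and a bromine enters. Against the 2,6-dimethoxyphenyl group, the result is a 5.0-fold lower number from compound 1 to compound 3 (0.70 log units; beyond the scatter), so each of the two five-membered aromatic rings now gives a number clearly lower than that of compound 1. Nothing available accounts for this likeness between the two rings.

The compounds shown leave open what the bromine and the ring sulfur each do on their own, since both change together in this single step. They also leave open how an amine or a carboxylic acid in place of the bromine would read.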